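The source may hold more compounds than are shown below. What is called first, only, known or untested is meant among the compounds shown, and "the series" means these compounds.

Measured compounds:
- compound 1 `CC(C)OC(=O)c1cccc(O)c1C(=O)c1c(O)cc(C(=O)O[C@@H]2CCC[C@H]2NC(=O)c2ccc(O)cc2)cc1O` — 13000 nM
- compound 2 `CCCCOC(=O)c1cccc(O)c1C(=O)c1c(O)cc(C(=O)O[C@@H]2CNC[C@H]2NC(=O)c2ccc(O)cc2)cc1O` — 3700 nM
- compound 3 `CC(=O)OCOC(=O)c1cccc(O)c1C(=O)c1c(O)cc(C(=O)O[C@@H]2CNC[C@H]2NC(=O)c2ccc(O)cc2)cc1O` — 130 nM

In an in vitro assay on Sf-9 cells for inhibition of protein kinase C epsilon type (Homo sapiens) (on this read-out higher numbers stand for weaker inhibition and lower numbers for stronger inhibition), compound 2 stands second highest of the three numbers. Going by the values given here, compound 1 gives 13000 nM, the higher of the two, but it differs from compound 2 at more than one place, so no single step is drawn between them. The nearest single-point comparison is a 28-fold lower number from compound 2 to compound 3 (1.45 log units; beyond the scatter), which shows that the ester chain on the shared core is a place where the number moves strongly.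

Compound 4 `CCOC(=O)c1cccc(O)c1C(=O)c1c(O)cc(C(=O)O[C@@H]2CNC[C@H]2NC(=O)c2ccc(O)cc2)cc1O` is the next point on the same chain: hydrogen in place of ethyl on a saturated chain carbon, two bonds along the chain from an oxygen next to a carbonyl group. Among the compounds with values here, this shortening has no direct precedent in the measured set; the only step at this chain, from compound 2 to compound 3, introduces a new group rather than removing carbons, so it gives no direction for a plain shortening. With a single bearing step of that kind, the expectation is a step near or within the scatter, a 1.2-fold lower number from compound 2 to compound 4 (0.09 log units; within the scatter), with wide uncertainty either way.

Compound 4 is therefore estimated at 3000 nM in this assay, with a range of 900 nM to 10000 nM.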

Compound 4, half-maximal inhibitory concentration: 1300 nM
The estimate for compound 4 lay 2.3-fold (0.36 log units) above the measured number; measured number inside the range.
By their numbers in this assay, from the lowest: compound 3; then compound 4; then compound 2; then compound 1.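

In this assay, going by these compounds alone, shortening the ester chain from butyl to ethyl is not a silent change: a 2.8-fold lower number from compound 2 to compound 4 (0.45 log units; beyond the scatter), a modest step, and the first reading of plain chain length at this place, since the earlier step at this chain brought in a new group. The acetoxy group of compound 3 keeps a clear lead over the shorter chain, with a 10-fold higher number from compound 3 to compound 4 (1.00 log units; beyond the scatter), so only part of the large drop in a 28-fold lower number from compound 2 to compound 3 (1.45 log units; beyond the scatter) goes with losing chain carbons and the greater part stays with the acetoxy end. No measured evidence bears on why the number moves with either change.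

The compounds shown leave open whether the lower number continues with a methyl ester, and how a free carboxylic acid or a longer chain such as hexyl would read at this place. They also leave open whether a similar ending such as propionyloxymethyl would hold the lead of compound 3, and compound 1 differs from the others at more than one place, so it adds no reading of this position.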